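The source may hold more compounds than are shown below. What is called first, only, known or untested is meant among the compounds shown, and "the series" means these compounds.

Going by the values given here, in a physicochemical assay for lipophilicity, using the shake flask method, in phosphate buffer, measured as octanol-water partition, with a stated time of 24 h, at pH 7.4, tested at 100 uM (a lower number here means a more polar compound, a higher number a more lipophilic compound), compound 3 (`O=C(O)CS(=O)(=O)c1ccc(OCc2cccc(-c3ccccc3)c2)cc1`) gives 2.13, and this is the only number available so far. For compound 1 (`COc1cc(C)c(-c2cccc(COc3ccc4c(c3)SCC4CC(=O)O)c2)c(C)c1`) the entry reads "not determined" (no result reported), and for compound 2 (`Cc1cc(OCCCS(C)(=O)=O)cc(C)c1-c1cccc(COc2ccc(S(=O)(=O)CC(=O)O)cc2)c1`) it reads "not determined" (no result reported). Compound 3 therefore has nothing to be ranked against. Compound 4 (`Cc1ccc(-c2cccc(COc3ccc(S(=O)(=O)CC(=O)O)cc3)c2)c(Cl)c1`) has 2-chloro-4-methylphenyl in place of the phenyl of compound 3, on an aromatic carbon: 2-chloro-4-methylphenyl in place of phenyl on an aromatic carbon. Among the compounds with values here, no measured pair shows what such a swap does in this assay, so the expectation rests on the structural change alone, and it is a rise beyond the scatter. The expected change is a number 0.87 log units higher from compound 3 to compound 4 (beyond the scatter). For compound 4 the estimated value is 3, within a range of 2.6 to 3.5.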

Compound 4, distribution coefficient: 3.05
Compound 4: the middle estimate sits 0.05 log units below what was measured, within the range that was stated.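

In this assay the swap of phenyl for 2-chloro-4-methylphenyl, meta to a large group, gives a number 0.92 log units higher from compound 3 to compound 4 (beyond the scatter) and is the only step shown at this position. It shows that the number here can move with a change to this outer ring alone. Both groups count no hydrogen-bond donors or acceptors and no net charge, and the entering one differs by added carbon and chlorine. Still open, going by these compounds, is how the number would read with the chlorine or the methyl alone, or with an amine on this ring. Nothing available explains the size of the step.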